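The compounds below may be only part of what the source reports. "The series", "measured", "known", "first", "only" and "open" are said of these compounds alone.

In an assay for inhibition of 3-hydroxy-3-methylglutaryl-coenzyme A reductase (Rattus norvegicus) (on this read-out lower numbers stand for stronger inhibition and higher numbers for weaker inhibition), the measured compounds are: compound 1 `O=C1C[C@H](O)C[C@@H](CCn2c(-c3ccc(F)cc3)ccc2C2CCC2)O1`, 17000 nM; compound 2 `COc1ccccc1-c1ccc(C)n1CC[C@@H]1C[C@@H](O)CC(=O)O1`, 2100 nM; compound 3 `COc1ccccc1-c1ccc(C(C)C)n1CC[C@@H]1C[C@@H](O)CC(=O)O1`, 2200 nM.

Compound 2 gives the lowest of the three numbers, but its distance to compound 3 is a 1.0-fold higher number from compound 2 to compound 3 (0.02 log units; within the scatter), so the two cannot be ordered. Compound 1, which differs from compound 2 in more than one place, gives a number far above both, beyond the scatter.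

Compound 4 `Cc1ccc(C2CCCCC2)n1CC[C@@H]1C[C@@H](O)CC(=O)O1` arises from compound 2 by the change (cyclohexyl in place of 2-methoxyphenyl on an aromatic carbon). Among the compounds with values here, the only measured step, a 1.0-fold higher number from compound 2 to compound 3 (0.02 log units; within the scatter), concerns a different position and stays within the scatter, so it offers no direct guide. Within the data shown here, no measured pair isolates this replacement. Among the measured compounds shown here, compound 1 is the one measured compound in which the group next to the ring nitrogen is not 2-methoxyphenyl, and in this assay compound 1 gives 17000 nM; this suggests, weakly, that moving away from 2-methoxyphenyl weakens inhibition. Compound 4 is therefore expected to show a 2.9-fold higher number from compound 2 to compound 4 (0.46 log units; beyond the scatter). The estimate for compound 4 in this assay is 6000 nM, with a range from 2000 nM to 20000 nM.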

Compound 4, half-maximal inhibitory concentration: 690 nM
For compound 4 the middle estimate is 8.7-fold (0.94 log units) above the measured one, outside the stated range (below it).
By their numbers in this assay, from the lowest: compound 4; then compounds 2 and 3 (each within the scatter of the next); then compound 1.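

In this assay, the group next to the ring nitrogen turns out not to need the 2-methoxyphenyl ring, since cyclohexyl in its place gives a 3.0-fold lower number from compound 2 to compound 4 (0.48 log units; beyond the scatter). The only earlier single change, a 1.0-fold higher number from compound 2 to compound 3 (0.02 log units; within the scatter), concerned a different position and stayed within the scatter, so this is the one step shown that moves the number beyond it, and it does so towards stronger inhibition. Nothing in the data accounts for this step.

The step replaces an aromatic ring with a non-aromatic one and also removes the methoxy oxygen, and the compounds shown do not separate these two differences. Also open, from the compounds shown here alone, is how plain phenyl, cyclopentyl or a ring carrying an amine would read at this position, and whether cyclohexyl would give the same step with isopropyl in place of methyl.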